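The source may hold more compounds than are shown below. What is called first, only, known or untested is meant among the compounds shown, and "the series" means these compounds.

Compound 1, whose structure is `O=C(CCc1ccccc1)Nc1nc2ccccc2c(=O)s1`, was tested in an assay on CHO cells for displacement of a labelled ligand from adenosine receptor A3 (Homo sapiens), read by scintillation counting, with a stated time of 60 min (a higher number here means a weaker inhibitor, a lower number a stronger inhibitor), and gave 390 nM. Going by the values given here, of the three compounds measured so far it carries the highest number. Compound 2, `COc1cccc(CCCC(=O)Nc2nc3ccccc3c(=O)s2)c1`, gave 382 nM in this assay, a value that lies within the usual scatter of that of compound 1, so the two cannot be told apart. Compound 3, `O=C(C/C=C/c1ccccc1)Nc1nc2ccccc2c(=O)s1`, gave 158 nM in this assay, a lower number than compound 1 by a margin that lies beyond the scatter.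

Compound 4, `O=C(CCc1ccccc1Br)Nc1nc2ccccc2c(=O)s1`, has not yet been measured. It differs from compound 1 in one place: bromo in place of hydrogen on an aromatic carbon. Among the compounds with values here, no pair among the measured compounds shows this same change, so there is no measured step to lean on. The author expects the step from compound 1 to compound 4 to be small, a 1.3-fold lower number from compound 1 to compound 4 (0.11 log units; within the scatter), with neither direction certain and a result within the scatter quite possible. The estimate for compound 4 in this assay is 300 nM, with a range from 100 nM to 900 nM.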

Compound 4, inhibition constant: > 1000 nM
Compound 4: only a limit was reported; the forecaster's own chance of this, stated with the estimate: 5%; at least 3.3-fold (0.52 log units) between middle value and limit.
By their numbers in this assay, from the lowest: compound 3; then compounds 2 and 1 (each within the scatter of the next). At a limit, above all of these: compound 4.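

Going from phenyl to 2-bromophenyl, with bromo on an aromatic carbon ortho to a large group, gives an at least 2.5-fold higher number from compound 1 to compound 4 (0.40 log units; beyond the scatter) in this assay. This is the first single change shown on this aromatic ring, and it indicates that this position does not take bromo without a loss of affinity. Compound 4 is reported only as a limit and not as a number, so the step gives only a minimum size: the limit of > 1000 nM in this assay, at which 1 of the 4 values shown sits.

The compounds shown leave open whether a fluoro, a methyl or an amine at this same position would bring a similar loss, or whether the loss is particular to bromo. They also leave open how bromo would fare on another carbon of this ring, or on the ring of compound 3.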